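Bromo in place of fluoro: compound 3 to compound 4

A few compounds are considered here, and "the series" means these few. Any claim that something is new, unique, unknown or untested is made for them only; others in the source may bear on it.

Values in a functional assay on MCF7 cells (Homo sapiens) for cytotoxicity, read by MTT assay, with a stated time of 72 h; on this read-out lower numbers stand for stronger inhibition and higher numbers for weaker inhibition:
compound 1 `CNC(=O)c1cc(Oc2ccc(NC(=O)c3nn(-c4ccccc4F)c(=O)cc3C)cc2F)ccn1`: > 40000 nM, a limit of this assay, no number
compound 2 `Cc1cc(=O)n(-c2ccc(Br)cc2F)nc1C(=O)Nc1ccc(Oc2ncnc3sccc23)c(F)c1`: 13300 nM
compound 3 `O=C(Nc1ccc(Oc2ncnc3ccsc23)c(F)c1)c1nn(-c2ccc(F)cc2)ccc1=O`: 5720 nM

Compound 3 holds the lowest of the two numbers; compound 2 stands above it by a gap beyond the usual scatter. Compound 1 gives only a limit.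

Compound 4 `O=C(Nc1ccc(Oc2ncnc3ccsc23)c(F)c1)c1nn(-c2ccc(Br)cc2)ccc1=O` differs from compound 3 by bromo in place of fluoro on an aromatic carbon. Among the measured compounds shown here, no measured pair in the set shows this same change, so its effect is unknown here. The step of a 1.1-fold lower number from compound 3 to compound 4 (0.06 log units; within the scatter) is expected to be small, likely within the scatter, with no clear direction. Compound 4 is estimated at 5000 nM, with a range from 1500 nM to 16000 nM.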

Compound 4, half-maximal inhibitory concentration: 9620 nM
Compound 4: middle estimate off by 1.9-fold (0.28 log units), on the low side; measured number inside the range.
By their numbers in this assay, from the lowest: compounds 3, 4 and 2 (each within the scatter of the next, the first and the last beyond it). At a limit, above all of these: compound 1.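

Among the compounds shown here, this is the first matched pair for the 4-fluorophenyl position: in this assay, bromo in place of fluoro gives a 1.7-fold higher number from compound 3 to compound 4 (0.23 log units; within the scatter) as its only read step. On this read-out, the 4-fluorophenyl and 4-bromophenyl forms cannot be told apart, so the exchange of these two halogens leaves no measurable mark here. Nothing given here explains the step.

From the compounds shown here alone, whether an amine or a carboxylic acid at this position would move the number beyond the scatter stays open. One pair also cannot show whether the exchange reads the same on other cores.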